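Fluoro to methyl on the aromatic ring: compound 4

The source may hold more compounds than are shown below. What is called first, only, known or untested is meant among the compounds shown, and "the series" means these compounds.

Compound 3 `CC(C(=O)N1CCN(c2cccc(F)c2)CC1)N1C(=O)CCC1=O` gives 75% in a functional assay on the whole organism (strain Swiss) with Mus musculus as the target, in the maximal electroshock model, with a stated time of 0.25 h, at a dose of 100 mg/kg by the intraperitoneal route (on this read-out lower numbers stand for a weaker effect and higher numbers for a stronger effect at the one dose given), and stands level with compound 2 `CC(C(=O)N1CCN(c2ccccc2F)CC1)N1C(=O)CCC1=O`, which gives 75%; together these are the highest of the three numbers. Compound 1 `COc1cccc(N2CCN(C(=O)C(C)N3C(=O)CCC3=O)CC2)c1` gives 25%. The steps: a number 50 percentage points higher from compound 1 to compound 3 (beyond the scatter); a number 50 percentage points higher from compound 1 to compound 2 (beyond the scatter); no change at the digits printed from compound 2 to compound 3 (within the scatter).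

Compound 4 `Cc1cccc(N2CCN(C(=O)C(C)N3C(=O)CCC3=O)CC2)c1` differs from compound 3 by methyl in place of fluoro on an aromatic carbon.

Of the measured steps, only one touches the substituent on the aromatic carbon: fluoro in place of methoxy, a number 50 percentage points higher from compound 1 to compound 3 (beyond the scatter), a large step. The step of no change at the digits printed from compound 2 to compound 3 (within the scatter) shows that moving fluoro on the ring left the read-out unchanged. Among the compounds with values here, no measured compound carries methyl, so there is no step that tells how methyl compares with fluoro or methoxy. Within the data shown here, the one relevant step is large, which means the read-out is sensitive to what sits on this carbon, but its direction for methyl is not given. The expectation is therefore wide, centred somewhat below compound 3, a number 15 percentage points lower from compound 3 to compound 4 (beyond the scatter). Compound 4 is estimated at 60%, with a range from 25% to 90%.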

Compound 4, a percentage reported as activity, at one dose (the size of the read-out at that dose, not a potency): 0%
Beside the measured number, compound 4's estimate is 60 percentage points above it; the whole stated range lies above it.
By their numbers in this assay, from the lowest: compound 4; then compound 1; then compounds 2 and 3 (each within the scatter of the next).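

In this assay, methyl on this aromatic carbon sits at the bottom of the series (a number 75 percentage points lower from compound 3 to compound 4 (beyond the scatter)), so the sensitivity seen earlier for fluoro against methoxy is not confined to methoxy as the poorer partner. Methyl also falls short of methoxy itself (a number 25 percentage points lower from compound 1 to compound 4 (beyond the scatter)), which gives this carbon a three-member order among the compounds shown: methyl, then methoxy, then fluoro, each gap beyond the scatter. The loss is just as large against the 2-fluorophenyl compound (a number 75 percentage points lower from compound 2 to compound 4 (beyond the scatter)), so 3-methylphenyl falls well short of both fluorophenyl variants, and a swap of one heavy atom for one heavy atom is enough to remove the read-out in this assay.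

No measurement on hand accounts for this order. Still open is where chloro, trifluoromethyl, hydroxyl or an amine on this carbon would fall in that order, and whether the result for compound 4 at the one dose and one time shown would hold at other doses or times.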